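The compounds below may be only part of what the source reports. "The series", "measured", "known", "first", "only" and "open" are said of these compounds alone.

Measured so far in an assay on isolated protein for inhibition of homeodomain-interacting protein kinase 1 (Homo sapiens), read by AlphaScreen, with a stated time of 1 h; on this read-out higher numbers stand for weaker inhibition and lower numbers for stronger inhibition:

compound 1, `c1ccc(Nc2cncc3nc(-c4ccc(N5CCCCC5)cc4)cnc23)cc1`: compound 1 gives > 100000 nM, a limit of the assay.
compound 2, `COc1ccccc1Nc1nccc2nc(-c3ccccc3)cnc12`: compound 2 gives > 100000 nM, likewise a limit of the assay.

Neither value is a number; both sit at the limit of > 100000 nM in this assay, at which 2 of the 2 values shown sit. Compound 2 therefore stands at that limit, with nothing measured beyond it, and the same holds for compound 1, so no ordering of the two can be read from this assay.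

The next compound in the series is compound 3, `COc1ccc(Nc2nccc3nc(-c4ccccc4)cnc23)cc1`. It keeps every atom of compound 2 and differs only in how they are joined: 4-methoxyphenyl in place of 2-methoxyphenyl on a nitrogen on an aromatic ring.

Among the measured compounds shown here, no step between two measured compounds is available for this assay, so there is no measured shift to lean on. With compound 2 at the limit, the expectation for compound 3 is a step of no more than the usual scatter, in no clear direction, a number no higher from compound 2 to compound 3 (the limit leaves the size open). Compound 3 is accordingly estimated to remain at or near the limit in this assay, about 100000 nM, within the range 30000 nM to 300000 nM.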

Compound 3, half-maximal inhibitory concentration: > 100000 nM
Compound 3: no number, only a limit; the forecaster's own chance of this, stated with the estimate: 80%; the middle value sits exactly at the limit.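

In this assay, compound 2 and compound 3 both stand at a limit of the assay, so no step between them can be read: the limit of > 100000 nM in this assay, at which 3 of the 3 values shown sit.

The compounds shown leave open how 4-methoxyphenyl and 2-methoxyphenyl compare on a nitrogen on an aromatic ring, and what structure would give a number rather than a limit in this assay.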